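Phenyl for pyridin-4-yl on the shared core

This account rests on a few compounds, and the source may have more. Where it says the series, first, only, none or still open, it means among the compounds named here.

For the measured compounds named here, compound 1 `C(=C/c1nn2c(-c3ccncc3)nnc2s1)\c1ccco1` stands highest of the two numbers measured so far in an assay for inhibition of histone-lysine N-methyltransferase, H3 lysine-79 specific (Homo sapiens), read by scintillation counting, with stated times of 15 min and 60 min, tested at 50 uM, in the presence of a further agent that is not named here; a higher number here means a stronger effect of the compound at the concentration tested, a lower number a weaker effect: compound 1 gives 67%. Compound 2 `Cc1occc1-c1nnc2sc(CCc3ccccc3)nn12`, which carries a methylfuran and a phenethyl chain on the shared core, gives 11% in this assay, a gap to compound 1 that lies beyond the scatter; the two compounds differ in more than one place, so their values alone say nothing about any single change.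

Compound 3 `C(=C/c1nn2c(-c3ccccc3)nnc2s1)\c1ccco1` has not been measured. It differs from compound 1 as follows: phenyl in place of pyridin-4-yl on an aromatic carbon. Going by the values given here, no measured pair shows this change, so its size is unknown. The change removes only the ring nitrogen while the rest of compound 1 is kept; a moderate step is expected, most likely a decrease that may stay within the scatter or go a little beyond it, as reflected in the estimated step of a number 12 percentage points lower from compound 1 to compound 3 (beyond the scatter). For compound 3 the expected value in this assay is 55%, with a range from 25% to 80%.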

Compound 3, a percentage reported as inhibition, at one concentration (the size of the read-out at that concentration, not a potency): 79%
Compound 3: the middle estimate sits 24 percentage points below what was measured, within the range that was stated.
By their numbers in this assay, from the lowest: compound 2; then compound 1; then compound 3.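

For the compounds shown here, on an aromatic carbon between two ring nitrogen atoms, this is the first comparison that isolates a single change: in this assay, phenyl in place of pyridin-4-yl gives a number 12 percentage points higher from compound 1 to compound 3 (beyond the scatter). The ring nitrogen of pyridin-4-yl, with the hydrogen-bond acceptor counted on that group, is therefore not required for the read-out at this position, and the all-carbon ring is the better of the two groups here, by a modest margin at the single concentration tested. Nothing measured on these compounds bears on the reason for this step.

The compounds shown leave open whether this position tolerates anything other than an unsubstituted six-membered aromatic ring, for example a phenyl carrying an amine, a carboxylic acid or a methoxy group, or a pyridin-3-yl or a saturated piperidine ring in the same place. They also leave open whether the gain from phenyl holds when the furan-bearing side of compound 3 is replaced by another group, such as a longer chain or a plain phenyl, and whether it would appear as a potency rather than a single-concentration percentage.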